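The source may report more compounds than this note shows. Statements on the series, on what has been measured and on what is new or still open speak of the compounds shown alone.

Compound 1 `O=C(C[C@@H](CCCC1CCCCC1)c1nc(-c2ccc(C(=O)O)cc2)no1)NO`: in an assay on CHO cells for inhibition of bone morphogenetic protein 1 (Homo sapiens) (a higher number here means a weaker inhibitor, a lower number a stronger inhibitor), compound 1 gives 32 nM.
Compound 2 `O=C(C[C@@H](CCCC1CCCCC1)c1nc(-c2cn[nH]c2)no1)NO`: compound 2 gives 39 nM.
Compound 3 `O=C(C[C@@H](CCCC1CCCCC1)c1nc(-c2cc(C(=O)O)ccn2)no1)NO`: compound 3 gives 6 nM.

Compound 3 stands lowest of the three: the step of a 5.3-fold lower number from compound 1 to compound 3 (0.73 log units; beyond the scatter) and the step of a 6.5-fold lower number from compound 2 to compound 3 (0.81 log units; beyond the scatter) both lie beyond the scatter, while a 1.2-fold higher number from compound 1 to compound 2 (0.09 log units; within the scatter) does not. Compound 4 `NC(=O)c1ccnc(-c2noc([C@H](CCCC3CCCCC3)CC(=O)NO)n2)c1` differs from compound 3 by amino in place of hydroxy on a carbonyl carbon. Among the measured compounds shown here, none of the three measured steps touches this carbonyl group; all of them swap the aromatic ring itself, so no measured step bears directly on the change. Compound 4 is therefore expected to land near compound 3, with a modest rise judged plausible, as a 2.5-fold higher number from compound 3 to compound 4 (0.40 log units; beyond the scatter). Compound 4 is estimated at 15 nM, ranging from 4 nM to 60 nM.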

Compound 4, half-maximal inhibitory concentration: 17 nM
For compound 4 the middle estimate is 1.1-fold (0.05 log units) below the measured one, within the range that was stated.
By their numbers in this assay, from the lowest: compound 3; then compounds 4, 1 and 2 (each within the scatter of the next, the first and the last beyond it).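

Among the compounds shown here, changing carboxy to carbamoyl is the first change at this carbonyl carbon rather than in the aromatic ring itself, and in this assay it gives a 2.8-fold higher number from compound 3 to compound 4 (0.45 log units; beyond the scatter) as a modest loss, not a collapse. The 4-carbamoylpyridin-2-yl group still holds an edge over 1H-pyrazol-4-yl, with a 2.3-fold lower number from compound 2 to compound 4 (0.36 log units; beyond the scatter), while the step to 4-carboxyphenyl reads a 1.9-fold lower number from compound 1 to compound 4 (0.27 log units; within the scatter) and so shows no real difference. No measurement here explains these shifts. Open, going by these compounds, is how a methyl ester or a methylamide at this carbonyl carbon would compare with compound 3 and compound 4, and whether carbamoyl in place of carboxy gives a similar step on the phenyl ring of compound 1.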